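A few compounds are considered here, and "the series" means these few. Any claim that something is new, unique, unknown or untested is made for them only; others in the source may bear on it.

Working notes on the series.

Compound 1 `C=CC(=O)Nc1cccc(Nc2ncnc(Nc3ccc(-c4cccnc4)cc3)n2)c1` carries a hydrogen on the aromatic carbon in question; in a functional assay on Raji cells (Homo sapiens) for antiproliferative activity, read by CCK-8 assay, with a stated time of 24 h (on this read-out higher numbers stand for weaker inhibition and lower numbers for stronger inhibition), compound 1 gives 12400 nM. Compound 2 `C=CC(=O)Nc1cccc(Nc2ncnc(Nc3ccc(-c4ccc(C)nc4)cc3)n2)c1` carries a methyl there, and in this assay compound 2 gives 13800 nM. Among the compounds with values here, the one measured step, a 1.1-fold higher number from compound 1 to compound 2 (0.05 log units; within the scatter), shows that the methyl in place of hydrogen on this aromatic carbon leaves the number where it was. Compound 2 thus stands with the higher of the two numbers, its nearest neighbour being compound 1, but the two values lie within the scatter of each other, so no order between them can be read.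

Compound 3 `C=CC(=O)Nc1cccc(Nc2ncnc(Nc3ccc(-c4ccc(F)nc4)cc3)n2)c1` is not yet measured in this assay. It differs from compound 2 by fluoro in place of methyl on an aromatic carbon. Within the data shown here, the only step that bears on this position is the one from compound 1 to compound 2, and it was within the scatter; no measured step exchanges methyl for fluoro. On that basis the step of a 1.1-fold lower number from compound 2 to compound 3 (0.03 log units; within the scatter) is expected to stay within the scatter, with no clear direction. Compound 3 is therefore estimated at 13000 nM, in the range 6000 nM to 28000 nM.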

Compound 3, half-maximal inhibitory concentration: 3250 nM
The estimate for compound 3 lay 4.0-fold (0.60 log units) above the measured number, outside the stated range (below it).
By their numbers in this assay, from the lowest: compound 3; then compounds 1 and 2 (each within the scatter of the next).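

The position is not indifferent to substitution in this assay: the methyl of compound 2 could not be told from the hydrogen of compound 1, but the fluoro gives a 4.2-fold lower number from compound 2 to compound 3 (0.63 log units; beyond the scatter) and a 3.8-fold lower number from compound 1 to compound 3 (0.58 log units; beyond the scatter). Both steps lie beyond the scatter, so compound 3, with its 6-fluoropyridin-3-yl group, separates from the other two and has the lowest number of the three, and the difference appears on an aromatic carbon next to the ring nitrogen and para to a large group. The exchange swaps one heavy atom for one heavy atom, with no ring, hydrogen-bond donor, hydrogen-bond acceptor or net charge on either side, and nothing available here accounts for the gain.

Going by these compounds, with a single fluoro example, it remains open whether the lower number is particular to fluorine or extends to other replacements at this carbon, such as chloro, methoxy, an amine or a nitrile. On these data alone, it also remains open whether the same exchange would give a step of similar size on a different core, or in any read-out other than this assay.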